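Swapping the aryl group on a pyrazole-urea TRPV1 antagonist

The source may report more compounds than this note shows. Statements on the series, on what has been measured and on what is new or still open speak of the compounds shown alone.

Compound 2 `CC(C)(C)c1ccc(-n2nc(C(C)(C)C)cc2CNC(=O)Nc2cccc3[nH]ncc23)cc1`: 40 nM
Compound 1 `COc1ccc(-n2nc(C(C)(C)C)cc2CNC(=O)Nc2cccc3[nH]ncc23)cc1`: 62.9 nM

Two compounds share a core and differ in one group. In an assay on CHO-K1 cells for antagonist activity at transient receptor potential cation channel subfamily V member 1 (Homo sapiens), read by FLIPR and calcium flux, with a stated time of 6 min (on this read-out lower numbers stand for stronger inhibition and higher numbers for weaker inhibition), compound 2 gives 40 nM and compound 1 gives 62.9 nM. For the measured compounds named here, compound 2 holds the lowest of the two numbers; its only neighbour is compound 1, and the step of a 1.6-fold lower number from compound 1 to compound 2 (0.20 log units; within the scatter) lies within the scatter, so the two cannot be ordered.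

Compound 3 `CC(C)(C)c1cc(CNC(=O)Nc2cccc3[nH]ncc23)n(-c2ccc(F)c(F)c2)n1` is not yet measured. It differs from compound 2 by 3,4-difluorophenyl in place of 4-(tert-butyl)phenyl on an aromatic nitrogen. Going by the values given here, the single measured step, a 1.6-fold lower number from compound 1 to compound 2 (0.20 log units; within the scatter), is the only one that bears on a change at this position, and it is within the scatter. Nothing in the data favours a direction for the new aryl group. Compound 3 is therefore expected to stay close to compound 2, with a step of about a 1.4-fold higher number from compound 2 to compound 3 (0.14 log units; within the scatter) in this assay, and an estimated value of 55 nM with a range from 18 nM to 170 nM.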

Compound 3, inhibition constant: 0.5 nM
Estimate against measurement, compound 3: 110-fold (2.04 log units) above, and the stated range ends above it.
By their numbers in this assay, from the lowest: compound 3; then compounds 2 and 1 (each within the scatter of the next).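

Replacing the group on the aromatic nitrogen can move the number in this assay a long way: with 3,4-difluorophenyl in place of 4-(tert-butyl)phenyl there is an 80-fold lower number from compound 2 to compound 3 (1.90 log units; beyond the scatter), and with it in place of 4-methoxyphenyl there is a 130-fold lower number from compound 1 to compound 3 (2.10 log units; beyond the scatter). The earlier step, a 1.6-fold lower number from compound 1 to compound 2 (0.20 log units; within the scatter), gave no sign of this, so the flat picture it offered holds only for the two groups it compared. Nothing available here explains the size of these steps.

The compounds shown leave open whether both fluorine atoms are needed, or whether 4-fluorophenyl, 3-fluorophenyl or 3,4-dichlorophenyl would give a similar number. They also leave open whether the same steps would appear with trifluoromethyl in place of the tert-butyl group on the five-membered ring.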